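The source may report more compounds than this note shows. Statements on the series, on what has been measured and on what is new or still open speak of the compounds shown alone.

Measured compounds:
Compound 1, `O=C(Nc1cccc(-n2cc(-c3ccncc3)c(-c3ccc(Cl)c(O)c3)n2)c1)Nc1cccc(C(F)(F)F)c1` — 3830 nM
Compound 2, `COc1cc(-c2nn(-c3cccc(NC(=O)Nc4cc(C(F)(F)F)cc(C(F)(F)F)c4)c3)cc2-c2ccncc2)ccc1Cl` — 715 nM
Compound 3, `COc1cc(-c2nn(-c3cccc(NC(=O)Nc4cccc(C(F)(F)F)c4)c3)cc2-c2ccncc2)ccc1Cl` — 1230 nM

The three compounds were tested in a functional assay on SW-620 cells (Homo sapiens) for inhibition, read by sulforhodamine B assay, with a stated time of 48 h; on this read-out lower numbers stand for stronger inhibition of growth and higher numbers for weaker inhibition of growth. Compound 2 sits at the low end of the range: compound 1 is clearly separated from it, whereas the gap a 1.7-fold higher number from compound 2 to compound 3 (0.24 log units; within the scatter) lies within the scatter, so compound 2 and compound 3 cannot be ordered against each other.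

The next compound, compound 4, `O=C(Nc1cccc(-n2cc(-c3ccncc3)c(-c3ccc(Cl)c(O)c3)n2)c1)Nc1cc(C(F)(F)F)cc(C(F)(F)F)c1`, is compound 2 with one change: hydrogen in place of methyl on an oxygen on an aromatic ring. Going by the values given here, only one measured step speaks directly to this change, and it runs the opposite way: a 3.1-fold lower number from compound 1 to compound 3 (0.49 log units; beyond the scatter). That step says that putting the methyl on the oxygen lowered the number by a modest, real amount, so removing it in compound 4 is expected to raise the number by a similar amount. The other step, a 1.7-fold higher number from compound 2 to compound 3 (0.24 log units; within the scatter), concerns a different position and is within the scatter, so it gives no guidance here.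

For compound 4 the expected step is therefore a 3.1-fold higher number from compound 2 to compound 4 (0.49 log units; beyond the scatter), a modest move towards weaker inhibition of growth, and the estimated value is 2200 nM, with a range of 1100 nM to 4500 nM.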

Compound 4, concentration for 50% growth inhibition: 1300 nM
Beside the measured number, compound 4's estimate is 1.7-fold (0.23 log units) above it, within the range that was stated.
By their numbers in this assay, from the lowest: compounds 2, 3 and 4 (each within the scatter of the next); then compound 1.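

Methoxy to hydroxy now has a second reading in this assay, a 1.8-fold higher number from compound 2 to compound 4 (0.26 log units; within the scatter), so on this core the two groups cannot be ordered, although the first reading of this change lay beyond the scatter. The two readings still agree with each other, so the data give no sign that the change behaves differently on the two cores: the same change on two cores in this assay, a 3.1-fold lower number (0.49 log units; beyond the scatter) from compound 1 to compound 3 and a 1.8-fold lower number (0.26 log units; within the scatter) from compound 4 to compound 2, 1.7-fold (0.23 log units) apart, within the scatter of two such steps

Trifluoromethyl in place of hydrogen on an aromatic carbon can also be read a second time, now with hydroxy on the other side of the molecule, and gives a 2.9-fold lower number from compound 1 to compound 4 (0.47 log units; beyond the scatter), a step beyond the scatter where the reading with methoxy was within it, yet these two readings agree as well: the same change on two cores in this assay, a 1.7-fold higher number (0.24 log units; within the scatter) from compound 2 to compound 3 and a 2.9-fold higher number (0.47 log units; beyond the scatter) from compound 4 to compound 1, 1.7-fold (0.23 log units) apart, within the scatter of two such steps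

Only hydrogen and methyl are seen on that oxygen, so the compounds shown leave open what an ethyl group, a longer chain or an amine in place of the oxygen would do to the number. They also do not tell whether a nitrile or a carboxylic acid in place of a trifluoromethyl would give a similar result.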